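Shared core series: chloro to methoxy on the pendant aryl

The source may report more compounds than this note shows. Statements on the series, on what has been measured and on what is new or still open speak of the compounds shown alone.

Measured compounds:
compound 1, `CCn1cc(-c2cccc(Cl)c2)c(=O)c2cc(F)c(N3CCNCC3)cc21`, 15300 nM
compound 2, `CCn1cc(-c2cccc(OC)c2)c(=O)c2cc(F)c(N3CCNCC3)cc21`, 13000 nM
compound 3, `O=c1c(-c2ccc(Cl)cc2)cn(C2CC2)c2cc(N3CCNCC3)c(F)cc12`, 8020 nM

All three numbers come from a functional assay on HepG2 cells (Homo sapiens) for antiproliferative activity, read by MTT assay, with a stated time of 48 h; a higher number here means a weaker inhibitor, a lower number a stronger inhibitor. Compound 1 and compound 2 share one core and differ in one place, (methoxy in place of chloro on an aromatic carbon), and the change gives a 1.2-fold lower number from compound 1 to compound 2 (0.07 log units; within the scatter). Compound 3 carries a different core; the difference between the two cores is not broken down here. Its value in this assay sits within the scatter of both compound 1 and compound 2, so no order among the three is claimed.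

Compound 4, `COc1ccc(-c2cn(C3CC3)c3cc(N4CCNCC4)c(F)cc3c2=O)cc1`, is not yet measured. It differs from compound 3 by methoxy in place of chloro on an aromatic carbon. Among the compounds with values here, this is the same kind of change as the one from compound 1 to compound 2, but the place is not identical: in the first pair the group stands meta to a large group, in the second pair para to a large group. Within the data shown here, with only one measured instance of the change, the expectation for compound 4 rests on that single step, a 1.2-fold lower number from compound 1 to compound 2 (0.07 log units; within the scatter), which stayed within the scatter. Compound 4 is therefore expected to move by about a 1.1-fold lower number from compound 3 to compound 4 (0.06 log units; within the scatter) in this assay. The estimate for compound 4 is 7000 nM, with a likely range from 3500 nM to 14000 nM.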

Compound 4, half-maximal inhibitory concentration: 20800 nM
Beside the measured number, compound 4's estimate is 3.0-fold (0.47 log units) below it, and the stated range ends below it.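

In this assay, methoxy in place of chloro on the core of compound 3 gives a 2.6-fold higher number from compound 3 to compound 4 (0.41 log units; beyond the scatter), so the 4-chlorophenyl to 4-methoxyphenyl change raises the number on this core, though only modestly. This does not show that the core alone sets the outcome: the two pairs differ in their core and also in where the group stands on the pendant aryl, and a single pair of each kind cannot separate those two differences or give a rule for either core. What the two pairs do show is that, in this series, the result of this change on one core cannot be assumed to hold for the other, as the steps on the two cores do not agree: the same change on two cores in this assay, a 1.2-fold lower number (0.07 log units; within the scatter) from compound 1 to compound 2 and a 2.6-fold higher number (0.41 log units; beyond the scatter) from compound 3 to compound 4, 3.1-fold (0.48 log units) apart, beyond the scatter of two such steps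

Still open, as far as these compounds go, is whether the gap follows the core or the place of the group, which would take chloro and methoxy compared at the same place on both cores. Within the data shown here, also open is how other groups on the pendant aryl, such as fluoro, methyl, hydroxy or an amine, would behave on these two cores, since chloro and methoxy are the only groups compared here.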